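Swapping Trifluoromethyl for Nitro in Compound 1

The source may hold more compounds than are shown below. What is called first, only, known or untested is meant among the compounds shown, and "the series" means these compounds.

Compound 1 `O=[N+]([O-])c1ccc(-n2cc(-c3ccc(C(F)(F)F)cc3)cn2)cc1` was tested in a functional assay on BGC-823 cells (Homo sapiens) for cytotoxicity, read by MTT assay, with a stated time of 48 h (a higher number here means a weaker inhibitor, a lower number a stronger inhibitor), and compound 1 gives 13800 nM. Its companion compound 2 `O=[N+]([O-])c1ccc(-n2cc(-c3cc(C(F)(F)F)cc(C(F)(F)F)c3)cn2)cc1` gives 18500 nM in this assay; the gap between the two numbers lies within the scatter, so neither compound can be called the stronger inhibitor. Of the two numbers available, compound 1 carries the lower one.

Compound 3 `O=[N+]([O-])c1ccc(-c2cnn(-c3ccc([N+](=O)[O-])cc3)c2)cc1` has not yet been measured. It differs from compound 1 in one place: nitro in place of trifluoromethyl on an aromatic carbon, para to a large group. Going by the values given here, no measured pair in this set shows what such a swap does, so the expectation rests only on the two numbers in hand, both of which sit close together in this assay. The step of a 1.2-fold lower number from compound 1 to compound 3 (0.06 log units; within the scatter) is expected to be small, in no certain direction, and not clearly beyond the scatter. Compound 3 is therefore estimated at 12000 nM, with a range from 4000 nM to 40000 nM.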

Compound 3, half-maximal inhibitory concentration: 11900 nM
Beside the measured number, compound 3's estimate is 1.0-fold (0.00 log units) above it; the measured number falls inside the stated range.
By their numbers in this assay, from the lowest: compounds 3, 1 and 2 (each within the scatter of the next).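

In this assay, going by these compounds alone, nitro in place of trifluoromethyl on an aromatic carbon, para to a large group, gives a 1.2-fold lower number from compound 1 to compound 3 (0.06 log units; within the scatter), the first measured single change at this position, and it lies within the scatter. The change therefore has no effect here that can be told from the scatter, even though the entering nitro carries hydrogen-bond acceptors and a double bond outside the aromatic rings, neither of which trifluoromethyl has. No measurement here bears on why the number stays within the scatter across this swap, so the result stands as an observation without an explanation.

What the compounds shown leave open is whether this position is insensitive in general or only to these two groups, since a single swap cannot separate those readings, and an amine, a carboxylic acid or a longer chain such as butyl could behave quite differently there. They also leave open how much the nitro group shared by all three compounds contributes, which a replacement of it by an amine or a nitrile on the core of compound 1 would address.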